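Chloro to trifluoromethyl in the ethoxy aryl series

The source may hold more compounds than are shown below. What is called first, only, known or untested is meant among the compounds shown, and "the series" means these compounds.

Measured in a functional assay on HeLa cells (Homo sapiens) for antiproliferative activity, read by CCK-8 assay, with a stated time of 72 h; a lower number here means a stronger inhibitor, a higher number a weaker inhibitor:
compound 1 `CCOc1ccc(-c2cncnc2-c2cc(OC)c(OC)c(OC)c2)cc1`: 250 nM
compound 2 `CCOc1ccc(-c2cncnc2-c2cc(OC)c(OC)c(OC)c2)cc1F`: 470 nM
compound 3 `CCOc1ccc(-c2cncnc2-c2cc(OC)c(OC)c(OC)c2)cc1Cl`: 90 nM

Compound 3 gives the lowest number of the three, at 90 nM. Next is compound 4 `CCOc1ccc(-c2cncnc2-c2cc(OC)c(OC)c(OC)c2)cc1C(F)(F)F`, with trifluoromethyl in place of chloro on an aromatic carbon, ortho to an ethoxy group. Among the compounds with values here, two measured steps bear on this: a 2.8-fold lower number from compound 1 to compound 3 (0.44 log units; beyond the scatter) and a 5.2-fold lower number from compound 2 to compound 3 (0.72 log units; beyond the scatter). Against them, a 1.9-fold higher number from compound 1 to compound 2 (0.27 log units; within the scatter). Within the data shown here, no measured compound carries trifluoromethyl, so the direction is uncertain. Part of the chloro gain is expected to be lost in this assay, a modest move to a higher number. The expected change is a 2.4-fold higher number from compound 3 to compound 4 (0.39 log units; beyond the scatter). The estimate for compound 4 is 220 nM, with an expected range of 70 nM to 700 nM.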

Compound 4, half-maximal inhibitory concentration: 790 nM
The estimate for compound 4 lay 3.6-fold (0.56 log units) below the measured number; measured number outside the range, above it.
By their numbers in this assay, from the lowest: compound 3; then compounds 1, 2 and 4 (each within the scatter of the next, the first and the last beyond it).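

In this assay, within the data shown here, the chloro gain at this place, ortho to an ethoxy group, does not carry over to trifluoromethyl: an 8.8-fold higher number from compound 3 to compound 4 (0.94 log units; beyond the scatter) is the largest step so far. Trifluoromethyl is also the first group here to fall beyond the scatter on the weak side of hydrogen, with a 3.2-fold higher number from compound 1 to compound 4 (0.50 log units; beyond the scatter) as the step, while a 1.7-fold higher number from compound 2 to compound 4 (0.23 log units; within the scatter) leaves it level with fluoro. Nothing at hand explains why chloro and trifluoromethyl part so widely. Open, on these data alone, is whether bromo or methyl at this place would follow chloro or trifluoromethyl. Also open, as far as these compounds go, is whether a propoxy chain in place of ethoxy would keep the chloro gain.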